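Expected cytotoxicity of a pyrimidinylmethyl amide analogue

A few compounds are considered here, and "the series" means these few. Any claim that something is new, unique, unknown or untested is made for them only; others in the source may bear on it.

Measured compounds:
- compound 1, `Cc1cc(C)cc(S(=O)(=O)c2c(C(=O)NCC(=O)NCc3ccncc3)[nH]c3ccc(Cl)cc23)c1`: > 48900 nM
- compound 2, `Cc1cc(C)cc(S(=O)(=O)c2c(C(=O)NCc3cccc(F)c3F)[nH]c3ccc(Cl)cc23)c1`: > 51100 nM
- compound 3, `Cc1cc(C)cc(S(=O)(=O)c2c(C(=O)NC(C)C(=O)NC(C)c3ccccc3F)[nH]c3ccc(Cl)cc23)c1`: 15200 nM

Within the data shown here, in an ADME assay on MT4 cells (Homo sapiens) for cytotoxicity, read by MTT assay (on this read-out higher numbers stand for lower toxicity in this test and lower numbers for higher toxicity in this test), compound 3 gives 15200 nM, the only actual number among the three results. Compound 1 reached a limit of the test, > 48900 nM, as recorded in the limit of > 48900 nM in this assay, at which 1 of the 3 values shown sits. Compound 2 likewise reached a limit, > 51100 nM, recorded in the limit of > 51100 nM in this assay, at which 1 of the 3 values shown sits. Among the measured compounds shown here, the single step between measured compounds that differ in one place, a step that the two limits leave unreadable from compound 1 to compound 2, is therefore unreadable, and no measured step bears directly on the change considered here.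

Compound 4, `Cc1cc(C)cc(S(=O)(=O)c2c(C(=O)NC(C)C(=O)NCc3ccncn3)[nH]c3ccc(Cl)cc23)c1`, differs from compound 3 by (pyrimidin-4-yl)methyl in place of 1-(2-fluorophenyl)ethyl on an amide-type nitrogen. With no readable step to lean on, the expectation rests on the few results there are. Compound 4 is expected to give 35000 nM, within a range from 12000 nM to 100000 nM, which would mean a step of a 2.3-fold higher number from compound 3 to compound 4 (0.36 log units; beyond the scatter) toward lower toxicity. This lean rests on compound 1, whose amide also ends in an aromatic ring with ring nitrogen atoms and which in this assay reached a limit, > 48900 nM. A limit rather than a number is a real possibility for compound 4 too.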

Compound 4, half-maximal cytotoxic concentration: 28100 nM
Compound 4: middle estimate off by 1.2-fold (0.10 log units), on the high side; the measured number falls inside the stated range.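

In this assay, among these compounds, this gives the first readable step for a change on this amide-type nitrogen: a 1.8-fold higher number from compound 3 to compound 4 (0.27 log units; within the scatter), so putting (pyrimidin-4-yl)methyl in place of 1-(2-fluorophenyl)ethyl moves the read-out no further than repeated measurements can vary. The comparison with compound 2 yields only a floor, an at least 1.8-fold lower number from compound 2 to compound 4 (0.25 log units; that floor lies within the scatter), because compound 2 has a limit and not a number: the limit of > 51100 nM in this assay, at which 1 of the 4 values shown sits. The comparison with compound 1 is likewise only a floor, an at least 1.7-fold lower number from compound 1 to compound 4 (0.24 log units; that floor lies within the scatter), because compound 1 also has a limit and not a number: the limit of > 48900 nM in this assay, at which 1 of the 4 values shown sits.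

The change from compound 3 to compound 4 swaps the ring and removes the branching methyl on the carbon that carries it in a single move, so the compounds shown cannot say whether either alteration matters alone in this test. A plain benzyl group on the same nitrogen would separate those two alterations, while a chain ending in an amine or a carboxylic acid would test a kind of group that lies outside the aromatic rings seen here.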